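The source may report more compounds than this note shows. Statements on the series, on what has been measured and on what is new or still open speak of the compounds shown alone.

Measured compounds:
compound 1 `O=C1C(N2CCCCC2)=CC(=O)c2c1nc1n2[C@H]2OC[C@@H](O)[C@H]2OC1` gives > 8000 nM
compound 2 `O=C1C=C(NCc2ccccc2)C(=O)c2c1nc1n2[C@H]2OC[C@@H](O)[C@H]2OC1` gives > 8000 nM
compound 3 `O=C1C(N2CCC2)=CC(=O)c2c1nc1n2[C@H]2OC[C@@H](O)[C@H]2OC1` gives > 16000 nM

In a functional assay on ECa-109 cells for inhibition, with ECa-109 cell line (Homo sapiens) as the target, read by sulforhodamine B assay (on this read-out lower numbers stand for stronger inhibition and higher numbers for weaker inhibition), compound 2 gives > 8000 nM, which is a limit of the assay and not a number; it shares that limit with one other value, as the limit of > 8000 nM in this assay, at which 2 of the 3 values shown sit, shows. Compound 4 `O=C1C=C(Nc2cccc(F)c2)C(=O)c2c1nc1n2[C@H]2OC[C@@H](O)[C@H]2OC1` differs from compound 2 in one place: 3-fluorophenyl in place of benzyl on an amine nitrogen. Among the compounds with values here, the only step measured so far, a step that the two limits leave unreadable from compound 1 to compound 3, runs between two limits and concerns another part of the shared core, so its size cannot be read, as the limit of > 16000 nM in this assay, at which 1 of the 3 values shown sits, and the limit of > 8000 nM in this assay, at which 2 of the 3 values shown sit, show. Within the data shown here, no measured step bears on the change from compound 2 to compound 4. Compound 4 is therefore expected to stay near the limit, with an estimated step that the limit leaves unreadable from compound 2 to compound 4. Compound 4 is estimated at 12000 nM, between 3000 nM and 40000 nM.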

Compound 4, half-maximal inhibitory concentration: 7030 nM
Compound 4: middle estimate off by 1.7-fold (0.23 log units), on the high side, and the stated range covers the measured number.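

In this assay, within the data shown here, compound 4 gives 7030 nM, the only value so far that is a true number and not a limit, so this position can carry a group that gives a readable result. The change amounts to an at least 1.1-fold lower number from compound 2 to compound 4 (0.05 log units; that floor lies within the scatter), which alone does not establish a real gain. Its true size stays open because compound 2 sits at a limit: the limit of > 8000 nM in this assay, at which 2 of the 4 values shown sit.

A plain phenyl on the same amine nitrogen would separate the part played by the fluorine from that of replacing benzyl. As far as these compounds go, whether any group here can give much stronger inhibition also remains open.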